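Inverting a Ring Stereocentre at the Assay Limit

The compounds below may be only part of what the source reports. "The series", "measured", "known", "first", "only" and "open" are said of these compounds alone.

Measured in an ADME assay on Jejunum (Mus musculus, strain C57BL/6) for metabolic stability, read by HPLC, with a stated time of 12 h; a lower number here means that the compound disappears faster, a higher number that the compound lasts longer:
- Compound 1 `O=C(O)[C@H](CO)NC(=O)[C@H]1C[C@H](O)CN1`: > 12 h
- Compound 2 `O=C(O)[C@@H](CO)NC(=O)[C@H]1C[C@H](O)CN1`: > 12 h

Compound 2 gives > 12 h, which is a limit of the assay and not a number. Compound 1 gives > 12 h, which is also a limit.

Compound 3 `O=C(N[C@H](CO)C(=O)O)[C@@H]1C[C@H](O)CN1` is related to compound 2 by a single inversion: the two compounds have the same atoms and bonds and differ only in configuration as drawn: 1 of 3 stereo elements differ; a stereocentre at a saturated ring carbon is drawn R in compound 2 and S in compound 3. Among the measured compounds shown here, one measured step bears on this change, a step that the two limits leave unreadable from compound 1 to compound 2. It also changes only the configuration as drawn, but at a saturated chain carbon rather than a saturated ring carbon. Its size therefore cannot be carried over to the new step. The main guide is the limit of > 12 h in this assay, at which 2 of the 2 values shown sit, and the two compounds behind it share (the fact that compounds 1 and 2 differ only in the configuration as drawn).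

In this assay, no step beyond the scatter is expected, and no direction can be foreseen. The expected step is a step that the limit leaves unreadable from compound 2 to compound 3, and the assay will probably report only a limit again. For compound 3, the estimated half-life is 15 h, with an expected range from 9 h to 30 h.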

Compound 3, half-life: > 12 h
Compound 3: no number, only a limit (the forecaster's own chance of this, stated with the estimate: 85%); the middle value lies beyond the limit too.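

In this assay compound 3 gives > 12 h, which is a limit of the assay and not a number. Among the compounds shown here, compound 1, compound 2 and compound 3 all sit at this limit, so no step among them can be read. The compounds shown leave open whether the configuration at the saturated ring carbon or the saturated chain carbon affects the half-life at all.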